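This account rests on a few compounds, and the source may have more. Where it says the series, first, only, none or still open, it means among the compounds named here.

Working notes on the series.

Compound 2 `c1ccc(Cc2ccc3c(NCCCNCc4ccco4)ccnc3c2)cc1` gives 16000 nM in an ADME assay on HepG2 cells (Homo sapiens) for cytotoxicity, read by luminescence, CellTiter-Glo and ATP content, with a stated time of 72 h; on this read-out lower numbers stand for an effect already at smaller amounts and higher numbers for an effect only at larger amounts of compound; of the two numbers measured in this assay it is the highest, and compound 1 `CCC(CC)c1ccc2c(NCCCNCc3ccco3)ccnc2c1` stands nearest with 6760 nM. Among the measured compounds shown here, the single step measured so far within this assay is a 2.4-fold higher number from compound 1 to compound 2 (0.37 log units; beyond the scatter). Compound 3 `COc1ccc(-c2ccc3c(NCCCNCc4ccco4)ccnc3c2)cc1` has not been measured; relative to compound 2 the change is 4-methoxyphenyl in place of benzyl on an aromatic carbon. For the measured compounds named here, no measured step bears directly on this exchange: the one step measured concerns the replacement of pentan-3-yl by benzyl on the same aromatic carbon, and it is modest. For compound 3 a step of the kind that this assay would register as beyond the scatter is not expected; the estimate is a 1.1-fold lower number from compound 2 to compound 3 (0.06 log units; within the scatter), which keeps compound 3 close to compound 2 because of 16000 nM. Compound 3 is therefore expected to give about 14000 nM in this assay, with a range from 5000 nM to 40000 nM.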

Compound 3, half-maximal effective concentration: 6000 nM
The estimate for compound 3 lay 2.3-fold (0.37 log units) above the measured number, and the stated range covers the measured number.
By their numbers in this assay, from the lowest: compounds 3 and 1 (each within the scatter of the next); then compound 2.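

In this assay the exchange of benzyl for 4-methoxyphenyl on this aromatic carbon registers as a real step (a 2.7-fold lower number from compound 2 to compound 3 (0.43 log units; beyond the scatter)), and it runs in the opposite direction to the step from pentan-3-yl to benzyl (a 2.4-fold higher number from compound 1 to compound 2 (0.37 log units; beyond the scatter)). Pentan-3-yl and 4-methoxyphenyl cannot be told apart here (a 1.1-fold lower number from compound 1 to compound 3 (0.05 log units; within the scatter)), so among these three groups only the benzyl of compound 2 stands apart. A six-membered aromatic ring at this place does not by itself set the number: compound 3 carries one and stays level with compound 1, which has none, while compound 2 also carries one and stands apart from both. Nothing available explains why benzyl and 4-methoxyphenyl differ in this read-out.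

The compounds shown leave open how the step to compound 3 divides between the change in how the ring is attached and the methoxy group; a plain phenyl group on this carbon would bear on that. On these data alone, how the number responds to an amine or a carboxylic acid at this place, or to any change elsewhere on the shared core, also remains open.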